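Adding a (nitrooxy)methyl group to a short nitrate ester

A few compounds are considered here, and "the series" means these few. Any claim that something is new, unique, unknown or untested is made for them only; others in the source may bear on it.

Compound 3 `O=C(CCO[N+](=O)[O-])Oc1ccccc1C(=O)O` gives 37000 nM in a functional assay on aorta (Rattus norvegicus, strain Wistar), in the presence of a further agent that is not named here (a lower number here means that less compound is needed, a higher number that more compound is needed for the effect), the highest of the three numbers recorded so far. Its nearest neighbour is compound 1 `O=C(CCCO[N+](=O)[O-])Oc1ccccc1C(=O)O`, which gives 23000 nM; the step of a 1.6-fold higher number from compound 1 to compound 3 (0.21 log units; within the scatter) lies within the scatter. The furthest is compound 2 `O=C(CCCCC(CO[N+](=O)[O-])O[N+](=O)[O-])Oc1ccccc1C(=O)O`, which gives 3100 nM, a much lower number than compound 3.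

Compound 4 `O=C(CC(CO[N+](=O)[O-])O[N+](=O)[O-])Oc1ccccc1C(=O)O` has not yet been measured. It differs from compound 3 by (nitrooxy)methyl in place of hydrogen on a saturated chain carbon bound to an oxygen on an unsaturated carbon and a saturated chain carbon. For the measured compounds named here, no measured step reproduces this exact change. Going by the values given here, the only step measured between two compounds, from compound 1 to compound 3, concerns the placement of the nitrooxy group on the chain and did not move the number beyond the scatter. Among the compounds with values here, compound 2 is the one measured compound that, like compound 4, carries a (nitrooxy)methyl group, and its number stands well below that of compound 3; compound 2 also has a longer chain, so this comparison is only a partial guide.

On that basis a lower number is expected for compound 4 than for compound 3, with the step of a 4.6-fold lower number from compound 3 to compound 4 (0.67 log units; beyond the scatter) estimated to go beyond the scatter. Compound 4 is expected to give about 8000 nM, within a range from 2500 nM to 25000 nM.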

Compound 4, half-maximal effective concentration in the aorta assay: 9200 nM
Compound 4: middle estimate off by 1.2-fold (0.06 log units), on the low side; the measured number falls inside the stated range.
By their numbers in the aorta assay, from the lowest: compound 2; then compound 4; then compounds 1 and 3 (each within the scatter of the next).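

For the compounds shown here, in the aorta assay the entering (nitrooxy)methyl group produces a shift at this saturated chain carbon: the result is a 4.0-fold lower number from compound 3 to compound 4 (0.60 log units; beyond the scatter) and so goes past the scatter, which the only earlier step, a 1.6-fold higher number from compound 1 to compound 3 (0.21 log units; within the scatter), did not do. Compound 4 can also be reached from compound 1 by nitrooxy in place of hydrogen on a saturated chain carbon bound to two saturated chain carbons, and that reading gives a 2.5-fold lower number from compound 1 to compound 4 (0.40 log units; beyond the scatter), so the number falls along both routes into compound 4. In a physicochemical assay for acid dissociation, compound 3 gives 3.69 and compound 4 gives 3.69, which is no change at the digits printed from compound 3 to compound 4 (within the scatter), so the same change that lowers the number for the effect on aorta leaves the acid dissociation read-out where it stood.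

The compounds shown leave open whether a simple methyl or an amine in place of the (nitrooxy)methyl at this carbon would lower the number in the aorta assay in the same way, or whether the nitrooxy part of the group is needed. No evidence is at hand that would explain the lower number for compound 4.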